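Estimating Compound 4 from Its Brominated Neighbour

The source may report more compounds than this note shows. Statements on the series, on what has been measured and on what is new or still open speak of the compounds shown alone.

In a functional assay on MCF7 cells (Homo sapiens) for antiproliferative activity, read by sulforhodamine B assay, with a stated time of 48 h (a higher number here means a weaker inhibitor, a lower number a stronger inhibitor), compound 1 `COc1ccc(OC)c(/C=C/C(=O)C(=Cc2ccc(O)c(OC)c2)C(=O)/C=C/c2cc(OC)ccc2OC)c1` gives 400 nM, compound 2 `COc1ccc(/C=C/C(=O)C(=Cc2ccc(O)c(OC)c2)C(=O)/C=C/c2ccc(OC)cc2OC)c(OC)c1` gives 2140 nM, and compound 3 `COc1ccc(/C=C/C(=O)C(=Cc2cc(Br)c(O)c(OC)c2)C(=O)/C=C/c2ccc(OC)cc2OC)c(OC)c1` gives 2600 nM. Compound 3 therefore sits level with compound 2, and both are clearly weaker than compound 1. Compound 4 `COc1ccc(/C=C/C(=O)C(=Cc2ccc(OC)c(O)c2)C(=O)/C=C/c2ccc(OC)cc2OC)c(OC)c1` differs from compound 3 in one group: 3-hydroxy-4-methoxyphenyl in place of 3-bromo-4-hydroxy-5-methoxyphenyl on a double-bonded chain carbon bound to a double-bonded chain carbon. Among the measured compounds shown here, the only measured step that bears on this change is a 1.2-fold higher number from compound 2 to compound 3 (0.08 log units; within the scatter), for bromo in place of hydrogen on an aromatic carbon. For the measured compounds named here, no measured compound carries the 3-hydroxy-4-methoxyphenyl group, so the data suggest no direction, and no shift beyond the scatter is expected in this assay. The expected change is a 1.2-fold lower number from compound 3 to compound 4 (0.07 log units; within the scatter). For compound 4 the estimated value is 2200 nM, with an expected range of 800 nM to 6000 nM.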

Compound 4, half-maximal inhibitory concentration: 1600 nM
Compound 4: middle estimate off by 1.4-fold (0.14 log units), on the high side, and the stated range covers the measured number.
By their numbers in this assay, from the lowest: compound 1; then compounds 4, 2 and 3 (each within the scatter of the next).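

At this double-bonded chain carbon, 3-hydroxy-4-methoxyphenyl in place of 3-bromo-4-hydroxy-5-methoxyphenyl gives a 1.6-fold lower number from compound 3 to compound 4 (0.21 log units; within the scatter) in this assay. In place of 4-hydroxy-3-methoxyphenyl, it gives a 1.3-fold lower number from compound 2 to compound 4 (0.13 log units; within the scatter), so all three groups seen at this position remain within the scatter of one another. No measurement available here offers an explanation for this. The compounds shown leave open whether an amine or a carboxylic acid on this aromatic ring would move the number beyond the scatter. They also leave open whether these group changes would give similar results on the core of compound 1.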